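Moving One Fluorine on the Benzyl Side

The source may hold more compounds than are shown below. What is called first, only, known or untested is meant among the compounds shown, and "the series" means these compounds.

In a functional assay on RS4-11 cells (Homo sapiens) for inhibition, read by CCK-8 assay, with a stated time of 48 h, tested at 20 uM (a higher number here means more inhibition of growth at the concentration tested, a lower number less inhibition of growth), compound 2 `N#C/C(=C\c1ccccc1OS(=O)(=O)c1ccccc1[N+](=O)[O-])C(=O)Nc1nnc(Cc2ccc(F)cc2)s1` gives 61%. Compound 1 `N#C/C(=C\c1ccccc1OS(=O)(=O)c1ccc([N+](=O)[O-])cc1)C(=O)Nc1nnc(Cc2ccc(F)cc2)s1` gives 55% and compound 3 `N#C/C(=C\c1ccccc1OS(=O)(=O)c1ccc(F)cc1)C(=O)Nc1nnc(Cc2ccc(F)cc2)s1` gives 59%, so compound 2 stands within the scatter of both. Compound 4 `N#C/C(=C\c1ccccc1OS(=O)(=O)c1ccccc1[N+](=O)[O-])C(=O)Nc1nnc(Cc2cccc(F)c2)s1` differs from compound 2 in one group: 3-fluorophenyl in place of 4-fluorophenyl on a saturated chain carbon bound to an aromatic carbon, with 3-fluorophenyl in place of 4-fluorophenyl on a saturated chain carbon bound to an aromatic carbon. The measured steps all concern the other end of the molecule, the group on the sulfonyl sulfur: a number 6 percentage points higher from compound 1 to compound 2 (within the scatter), a number 4 percentage points higher from compound 1 to compound 3 (within the scatter) and a number 2 percentage points lower from compound 2 to compound 3 (within the scatter). None of them tests this fluorine shift, so they offer only indirect guidance, and no step beyond the scatter is expected. The estimated step is a number 3 percentage points lower from compound 2 to compound 4 (within the scatter). Compound 4 is expected near 58%, within a range of 44% to 72%.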

Compound 4, percent growth inhibition at one concentration: 68%
The estimate for compound 4 lay 10 percentage points below the measured number, within the range that was stated.
By their numbers in this assay, from the lowest: compounds 1, 3, 2 and 4 (each within the scatter of the next, the first and the last beyond it).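

Among the compounds shown, this is the only change on the benzyl side: in this assay, going from 4-fluorobenzyl to 3-fluorobenzyl gives a number 7 percentage points higher from compound 2 to compound 4 (within the scatter). For this one pair, then, moving the fluorine while keeping the same atoms leaves growth inhibition within the usual scatter. No measurement at hand offers an explanation for this result.

As far as these compounds go, whether a plain phenyl, a methoxyphenyl or an amine would fare the same in this place remains open. So does whether the fluorine shift would read the same with 4-fluorophenyl on the sulfonyl sulfur.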